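From Bromo to Chloro: A Small Swap in a Cytotoxicity Series

This account rests on a few compounds, and the source may have more. Where it says the series, first, only, none or still open, it means among the compounds named here.

In a functional assay on A549 cells (Homo sapiens) for cytotoxicity (on this read-out lower numbers stand for stronger inhibition and higher numbers for weaker inhibition), compound 1 (`Cc1ccc(C2CN(S(=O)(=O)c3ccccc3)C(=O)N2)cc1`) returns > 316000 nM as its result, which is a limit of the assay and not a number. Within the data shown here, compound 2 (`O=C1NC(c2ccc(Br)cc2)CN1S(=O)(=O)c1ccc2c(c1)CCC2`) gives 33900 nM in this assay and so holds the only true number available so far, which makes it the single reference point for what follows.

Compound 3 (`O=C1NC(c2ccc(Cl)cc2)CN1S(=O)(=O)c1ccc2c(c1)CCC2`) has not yet been measured. It carries chloro in place of bromo on an aromatic carbon, para to a large group, and the rest of compound 2 stays as it is (chloro in place of bromo on an aromatic carbon). Among the measured compounds shown here, no measured pair of compounds shows what such a swap does here, so the expectation rests only on compound 2 at 33900 nM and on how small the structural change is. The expected shift in this assay is none beyond the usual scatter, with a slight lean towards weaker inhibition if any shift appears. The estimated size of the move is a 1.2-fold higher number from compound 2 to compound 3 (0.07 log units; within the scatter) and it is expected to stay small. For compound 3 the estimated value is 40000 nM and the expected range runs from 15000 nM to 110000 nM in this measurement.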

Compound 3, half-maximal inhibitory concentration: 86300 nM
Estimate against measurement, compound 3: 2.2-fold (0.33 log units) below; measured number inside the range.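

In this assay, the change from 4-bromophenyl to 4-chlorophenyl gives a 2.5-fold higher number from compound 2 to compound 3 (0.41 log units; beyond the scatter), so this position on the aromatic ring is not indifferent to which of these two halogens it carries, and bromo gives the stronger inhibition of the pair. Only one atom is replaced by one other atom, with no ring, hydrogen-bond donor, hydrogen-bond acceptor or charge entering or leaving, yet that is enough to carry the result beyond the usual scatter, although the step remains modest. Compound 1 cannot join this comparison, since it differs from compound 2 in more than one place and its result is a limit of the assay and not a number: the limit of > 316000 nM in this assay, at which 1 of the 3 values shown sits.

From the compounds shown here alone, a single step cannot show whether the result follows a trend across the halogens, so it remains open how fluoro or iodo would behave at this position, or a different kind of group such as methoxy or an amine. Going by these compounds, it also remains open why chloro and bromo differ here, and whether the same swap would have a similar effect on a different core.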